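The source may hold more compounds than are shown below. What is called first, only, known or untested is meant among the compounds shown, and "the series" means these compounds.

Three compounds have been measured in an assay on isolated protein for inhibition of leukotriene B4 receptor 1 (Homo sapiens), tested at 10 uM; a lower number here means less inhibition, a higher number more inhibition at the concentration tested (going by the name of the read-out):

Compound 1 `C=CCc1cc(C(C)=O)c(O)cc1OCC#N` gives 20%.
Compound 2 `C=CCc1cc(C(C)=O)c(O)cc1OCCCCCC` gives 50%.
Compound 3 `C#CCCCCOc1cc(O)c(C(C)=O)cc1CC=C` gives 74%.

Compound 3 stands highest of the three. Its nearest neighbour is compound 2, separated by a number 24 percentage points higher from compound 2 to compound 3 (beyond the scatter), and the furthest is compound 1, separated by a number 54 percentage points higher from compound 1 to compound 3 (beyond the scatter). Both gaps lie beyond the scatter, so compound 3 gives the highest number of the measured set.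

Compound 4 `C=CCc1cc(C(C)=O)c(O)cc1OCCCCO` has not yet been measured. It differs from compound 3 in one place: hydroxy in place of ethynyl on a saturated chain carbon, four bonds along the chain from an oxygen on an aromatic ring. For the measured compounds named here, two measured steps bear on this. The ethynyl group that now leaves is the same one whose arrival produced a number 24 percentage points higher from compound 2 to compound 3 (beyond the scatter), so removing it points downward by roughly that amount. Going by the values given here, the group that enters brings a hydrogen-bond donor and acceptor to the chain, and the only measured compound with a group other than carbon and hydrogen on its chain, compound 1 with cyano, gives the lowest number; exchanging that cyano for pentyl gave a number 30 percentage points higher from compound 1 to compound 2 (beyond the scatter). A downward step beyond the scatter is therefore expected, a number 39 percentage points lower from compound 3 to compound 4 (beyond the scatter), of modest to large size. Compound 4 is estimated to give about 35%, within a range from 15% to 60%.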

Compound 4, a percentage reported as inhibition, at one concentration (the size of the read-out at that concentration, not a potency): 48%
The estimate for compound 4 lay 13 percentage points below the measured number; the range from low to high includes it.
By their numbers in this assay, from the lowest: compound 1; then compounds 4 and 2 (each within the scatter of the next); then compound 3.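

At this place, on a saturated chain carbon four bonds along the chain from an oxygen on an aromatic ring, hydroxy in place of ethynyl gives a number 26 percentage points lower from compound 3 to compound 4 (beyond the scatter) and hydroxy in place of ethyl gives a number 2 percentage points lower from compound 2 to compound 4 (within the scatter) so the ethyl and hydroxy ends cannot be told apart here, and among these three end groups only ethynyl stands out. The hydrogen-bond donor and acceptor that hydroxy brings to the chain therefore carry no measurable cost against ethyl, and 3-hydroxypropyl in place of cyano still gives a number 28 percentage points higher from compound 1 to compound 4 (beyond the scatter) so the low number of compound 1 does not extend to compound 4, even though both chains carry an atom other than carbon and hydrogen. Nothing available explains why ethynyl stands apart from the other two ends.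

From the compounds shown here alone, whether the number follows the end group more generally stays open, as an amine or a carboxylic acid at the same chain end would test that. A longer chain ending in hydroxy or ethynyl would show whether the distance from the core also matters.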